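A few compounds are considered here, and "the series" means these few. Any claim that something is new, unique, unknown or untested is made for them only; others in the source may bear on it.

Working notes on the series. Among the measured compounds shown here, in a functional assay on PC-3 cells (Homo sapiens) for inhibition, read by MTT assay, with a stated time of 24 h, tested at 100 ug/mL (on this read-out higher numbers stand for more inhibition of growth at the one concentration tested and lower numbers for less inhibition of growth), compound 1 (`O=C(CCCCC1CCSS1)Nc1ccc([N+](=O)[O-])c(C(F)(F)F)c1`) gives 90.3%, the only number available so far. For compound 2 (`O=C(CCCCC(S)CCS)Nc1cccc(C(F)(F)F)c1`) the entry reads "not determined" (no result reported), so compound 2 has no place on this scale and offers no baseline. The next structure is compound 3 (`O=C(CCCCC(S)CCS)Nc1ccc([N+](=O)[O-])c(C(F)(F)F)c1`). The structural change is nitro in place of hydrogen on an aromatic carbon, which amounts to nitro in place of hydrogen on an aromatic carbon, ortho to a trifluoromethyl group and para to a large group. A moderate upward step in this assay is expected for this change, although its size cannot be checked without a number for compound 2. The expectation leans on compound 1 at 90.3%, a single data point, so the range stays wide. For compound 3 the estimated value is 80%, with an expected range of 60% to 95%.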

Compound 3, percent growth inhibition at one concentration: 79.9%
The estimate for compound 3 lay 0.1 percentage points above the measured number, and the stated range covers the measured number.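

In this assay, with the nitro-bearing aromatic part held constant, the open group with no ring in place of the five-membered non-aromatic ring with 2 hetero atoms gives a number 10.4 percentage points lower from compound 1 to compound 3 (beyond the scatter). The change on this saturated chain carbon, four bonds along the chain from a carbonyl carbon, therefore registers on this read-out, although compound 3 still retains most of the growth inhibition seen for compound 1 at the one concentration tested. No supporting data bear on the origin of this step.

Compound 2 has no number, so the step from hydrogen to nitro cannot be read. Also open, going by these compounds, is how the series would respond to a nitrile or an amine in place of nitro, or to a longer chain in place of the present saturated chain.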